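The compounds below may be only part of what the source reports. "The series", "measured", "known", "first", "only" and "open" are said of these compounds alone.

Measured compounds:
- compound 1, `CCc1csc(CN[C@@H]2C[C@H]3C[C@@H]([C@H]2C)C3(C)C)c1`: 25000 nM
- compound 2, `C[C@H]1[C@H](NCc2ccsc2)C[C@H]2C[C@@H]1C2(C)C`: 50000 nM
- compound 3, `C=Cc1ccsc1CN[C@@H]1C[C@H]2C[C@@H]([C@H]1C)C2(C)C`: 50000 nM

All three values come from an ADME assay on MDCK cells (Canis lupus familiaris) for cytotoxicity, read by microscopy, with a stated time of 48 h; on this read-out lower numbers stand for higher toxicity in this test and higher numbers for lower toxicity in this test. Among the compounds with values here, on these numbers compound 1 stands at the low end of the three; compound 2 and compound 3 each sit within the usual scatter of it, so the three cannot be told apart on this read-out, and no compound can be called more or less toxic than another here. Within the data shown here, no pair among them differs in a single place, so no clean single-point step is available from the measured set.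

Compound 4, `C[C@H]1[C@H](NCc2cc(C3CC3)cs2)C[C@H]2C[C@@H]1C2(C)C`, is not yet measured in this assay . Compared with compound 1 the change is cyclopropyl in place of ethyl on an aromatic carbon. Both groups entering and leaving are small, carbon-only and carry neither donor nor acceptor, and the three measured compounds, which vary at the same ring, all fall within the scatter of one another. On that basis the step from compound 1 to compound 4 is expected to be none beyond the scatter, no change at the digits printed from compound 1 to compound 4 (within the scatter). For compound 4 the minimum cytotoxic concentration in this assay is therefore estimated at 25000 nM, with a range of 12500 nM to 50000 nM.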

Compound 4, minimum cytotoxic concentration: 25000 nM
Beside the measured number, compound 4's estimate shows no gap at the digits printed, and the stated range covers the measured number.
By their numbers in this assay, from the lowest: compounds 1, 4, 2 and 3 (each within the scatter of the next).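

In this assay, cyclopropyl in place of ethyl on an aromatic carbon, two ring bonds from the ring sulfur, gives no change at the digits printed from compound 1 to compound 4 (within the scatter). Within the data shown here, this is the first single-place comparison, as no pair among the earlier compounds differed in one place only, so their shared range could not be tied to any one position or group. At this place, exchanging an open ethyl group for a three-membered carbon ring therefore leaves the minimum cytotoxic concentration within the scatter, although no information bearing on the reason for this accompanies the result.

The compounds shown carry only carbon-only groups at this place, with neither donor nor acceptor, so it remains open whether an amine, a carboxylic acid or a longer chain here would give a step beyond the scatter. This single step also leaves open whether a similar exchange elsewhere on the shared core would behave the same way on this read-out.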